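Alpha-hydroxy amide side chain: chain length step

The source may report more compounds than this note shows. Statements on the series, on what has been measured and on what is new or still open speak of the compounds shown alone.

Measured so far:
compound 1 `CC1(C)Cc2c(sc(NC(=O)C3(O)CC3)c2C(N)=O)C(C)(C)O1` – 23 nM
compound 2 `CC1(C)Cc2c(sc(NC(=O)[C@H](O)C(C)(C)C)c2C(N)=O)C(C)(C)O1` – 127 nM

Among the compounds with values here, in an assay on cells for positive allosteric modulation of Cystic fibrosis transmembrane conductance regulator variant F508del (Homo sapiens), with stated times of 10 min and 7 s, in the presence of a further agent that is not named here (on this read-out higher numbers stand for an effect only at larger amounts of compound and lower numbers for an effect already at smaller amounts), compound 2 shows the higher of the two numbers; the only measured step, a 5.5-fold higher number from compound 1 to compound 2 (0.74 log units; beyond the scatter), puts compound 2 beyond the scatter from compound 1. Compound 3 `CC(C)(C)CC(O)C(=O)Nc1sc2c(c1C(N)=O)CC(C)(C)OC2(C)C` differs from compound 2 by a group of 7 heavy atoms (6 carbon, 1 oxygen; no ring) in place of a group of 6 heavy atoms (5 carbon, 1 oxygen; no ring), on a carbonyl carbon. Within the data shown here, no measured step covers this change, so the expectation rests on compound 2 alone. Compound 3 is expected to lie near compound 2, with at most a modest shift, estimated at 200 nM (range 60 nM to 700 nM), a step of a 1.6-fold higher number from compound 2 to compound 3 (0.20 log units; within the scatter).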

Compound 3, half-maximal effective concentration: 0.54 nM
Estimate against measurement, compound 3: 370-fold (2.57 log units) above; measured number outside the range, below it.
By their numbers in this assay, from the lowest: compound 3; then compound 1; then compound 2.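

On the carbonyl carbon, small changes in the side chain matter far more than the first pair suggested: one further heavy atom in the open-chain group gives a 240-fold lower number from compound 2 to compound 3 (2.37 log units; beyond the scatter). The open chain is also not inherently poorer than the 1-hydroxycyclopropyl group, as shown by a 43-fold lower number from compound 1 to compound 3 (1.63 log units; beyond the scatter). Nothing available explains the size of these steps.

Going by these compounds, compound 3 has no defined stereocentre, unlike compound 2, so the contribution of each stereoisomer remains open. Also open, on these data alone, is whether a longer chain, or an amine in place of the hydroxyl, would hold this level.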